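This account rests on a few compounds, and the source may have more. Where it says the series, first, only, none or still open, it means among the compounds named here.

For the measured compounds named here, compound 2 `COc1cc(O)cc(-c2ccccc2O)c1` gives the lowest of the two numbers measured so far in a functional assay on cells (Neutrophil, Homo sapiens) for inhibition, with a stated time of 5 min (a lower number here means a stronger inhibitor, a higher number a weaker inhibitor), at 2040 nM. Its nearest neighbour is compound 1 `COc1cc(O)cc(-c2ccccc2OC)c1`, which in this assay gives 8360 nM; the step of a 4.1-fold lower number from compound 1 to compound 2 (0.61 log units; beyond the scatter) came from hydrogen in place of methyl on an oxygen on an aromatic ring. Compound 3 `COc1cc(O)cc(-c2ccccc2)c1` differs from compound 2 by hydrogen in place of hydroxy on an aromatic carbon, on an aromatic carbon of a six-membered aromatic ring of carbon only, ortho to a group of 9 heavy atoms. Going by the values given here, no measured step removes the hydroxy outright, so the only guide is that the hydroxy of compound 2 sits at the lowest number seen, with compound 1 and its 8360 nM standing higher. Compound 3 is therefore expected to give a higher number than compound 2, a step of a 2.9-fold higher number from compound 2 to compound 3 (0.47 log units; beyond the scatter), with the estimate for compound 3 placed at 6000 nM, in a range from 2000 nM to 20000 nM.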

Compound 3, half-maximal inhibitory concentration: 34100 nM
Compound 3: the middle estimate sits 5.7-fold (0.75 log units) below what was measured, outside the stated range (above it).
By their numbers in this assay, from the lowest: compound 2; then compound 1; then compound 3.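

In this assay, the oxygen substituent on this aromatic carbon matters more than the earlier pair could show, since that pair changed only the methyl on the oxygen, whereas losing the hydroxy altogether gives a 17-fold higher number from compound 2 to compound 3 (1.22 log units; beyond the scatter), a large step. Removing the methoxy gives a 4.1-fold higher number from compound 1 to compound 3 (0.61 log units; beyond the scatter), so the methoxy of compound 1 keeps part of what the hydroxy of compound 2 gives, and both give lower numbers than the hydrogen of compound 3. Nothing measured here bears on why the oxygen counts at this place.

The compounds shown leave open whether another group on this aromatic carbon, such as an amine or a fluorine, would give a number near that of compound 2. They also leave open how an ethoxy or a longer chain on that oxygen would compare with the methoxy of compound 1.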